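A few compounds are considered here, and "the series" means these few. Any claim that something is new, unique, unknown or untested is made for them only; others in the source may bear on it.

Compound 3 `Cc1cccc(CNC(=O)n2c(N)nc3ccccc32)c1` gives 8.5 nM in an assay on HEK293 cells for inhibition of acid ceramidase (Homo sapiens), read by fluorescence, with stated times of 30 min and 1 h; a higher number here means a weaker inhibitor, a lower number a stronger inhibitor. Its two measured relatives are compound 1 `Cc1cccc(CNC(=O)n2cnc3ccccc32)c1`, which gives 8.3 nM in this assay, and compound 2 `Cc1ccc(CNC(=O)n2c(N)nc3ccccc32)cc1`, which gives 7 nM in this assay. The steps of a 1.0-fold higher number from compound 1 to compound 3 (0.01 log units; within the scatter) and a 1.2-fold higher number from compound 2 to compound 3 (0.08 log units; within the scatter) both lie within the scatter, so these three numbers cannot be told apart. Compound 4 `Nc1nc2ccccc2n1C(=O)NCc1ccccc1` differs from compound 3 by hydrogen in place of methyl on an aromatic carbon; the same difference, cut one bond further out, reads 3-methylphenyl to phenyl. Among the measured compounds shown here, only one measured step touches that methyl, a 1.2-fold higher number from compound 2 to compound 3 (0.08 log units; within the scatter), which moved it to another aromatic carbon without a change beyond the scatter; no measured step removes it. A step of a 1.1-fold higher number from compound 3 to compound 4 (0.02 log units; within the scatter) is therefore expected, within the scatter. Compound 4 is estimated at 9 nM, between 4 nM and 20 nM.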

Compound 4, half-maximal inhibitory concentration in the acid ceramidase assay: 29.3 nM
For compound 4 the middle estimate is 3.3-fold (0.51 log units) below the measured one; the whole stated range lies below it.
By their numbers in the acid ceramidase assay, from the lowest: compounds 2, 1 and 3 (each within the scatter of the next); then compound 4.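

In the acid ceramidase assay, removing the methyl from the aromatic ring gives a 3.4-fold higher number from compound 3 to compound 4 (0.54 log units; beyond the scatter) and a 4.2-fold higher number from compound 2 to compound 4 (0.62 log units; beyond the scatter), so its presence matters here, although moving it to another aromatic carbon gives only a 1.2-fold higher number from compound 2 to compound 3 (0.08 log units; within the scatter). In a physicochemical assay for metabolic stability, read by HPLC, at pH 4.5, tested at 10 uM (a lower number here means that the compound disappears faster, a higher number that the compound lasts longer), compound 3 gives 0.45 h and compound 4 gives 0.7 h; the same change gives a 1.6-fold higher number from compound 3 to compound 4 (0.19 log units; within the scatter), so this loss of inhibition comes without a readable change in half-life. Nothing available explains the effect of this single methyl.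

As far as these compounds go, whether an ethyl, a methoxy or a chlorine on this aromatic carbon would serve as well as the methyl remains open. So does whether removing the methyl has the same effect on compound 1, which lacks the amino group.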